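This account rests on a few compounds, and the source may have more. Where it says the series, first, only, none or still open, it means among the compounds named here.

Compound 1, `COc1cccc(OC)c1OCCNCCOc1ccccc1OCc1ccccc1Cl`, stands highest of the two numbers measured in a functional assay on Vas deferens for antagonist activity at Alpha-1A adrenergic receptor (Rattus norvegicus) (on this read-out higher numbers stand for higher potency (the scale is a negative logarithm) and lower numbers for lower potency), giving 8.56. Compound 2, `COc1cccc(OC)c1OCCNCCOc1ccccc1OCc1ccc(Cl)cc1`, gives 8.17, and the step of a number 0.39 log units lower from compound 1 to compound 2 (beyond the scatter). Compound 3, `COc1cccc(COc2ccccc2OCCNCCOc2c(OC)cccc2OC)c1`, differs from compound 1 in one place: 3-methoxyphenyl in place of 2-chlorophenyl on a saturated chain carbon bound to an oxygen on an aromatic ring. Among the measured compounds shown here, the only measured step that touches this same saturated chain carbon bound to an oxygen on an aromatic ring is the modest drop from compound 1 to compound 2, so a modest loss of potency is expected here too, as a number 0.36 log units lower from compound 1 to compound 3 (beyond the scatter). Compound 3 is therefore estimated at 8.2, with a likely range from 7.7 to 8.7.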

Compound 3, negative logarithm of the antagonist equilibrium constant: 8.3
Estimate against measurement, compound 3: 0.10 log units below; measured number inside the range.
By their numbers in this assay, from the lowest: compounds 2, 3 and 1 (each within the scatter of the next, the first and the last beyond it).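

In this assay the change to 3-methoxyphenyl gives a number 0.26 log units lower from compound 1 to compound 3 (within the scatter) and, starting from the other chlorophenyl compound, a number 0.13 log units higher from compound 2 to compound 3 (within the scatter) here. So 3-methoxyphenyl, with one hydrogen-bond acceptor where the chlorophenyl groups have none, cannot be told apart from either chlorophenyl compound, even though those two differ beyond the scatter. Nothing available gives a reason for this result. Still open, from the compounds shown here alone, is how this position would respond to a phenyl ring carrying an amine or a carboxylic acid, or to a longer chain linking the ring to the oxygen.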